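The source may hold more compounds than are shown below. What is called first, only, known or untested is meant among the compounds shown, and "the series" means these compounds.

Compound 1 `O=C(N/N=C/c1cccc(O)c1O)c1cc(-c2ccc(Cl)cc2)nn1Cc1ccc(Cl)nc1` carries a 2,3-dihydroxyphenyl hydrazone on the shared core. In a functional assay on A549 cells (Homo sapiens) for antiproliferative activity, read by BrdU incorporation, with a stated time of 48 h (on this read-out higher numbers stand for weaker inhibition and lower numbers for stronger inhibition), compound 1 gives 700 nM. Compound 2 `CC(C)(C)c1ccc(Cn2nc(-c3ccc(Cl)cc3)cc2C(=O)N/N=C/c2ccc(F)cc2F)cc1` combines a tert-butylbenzyl group with a 2,4-difluorophenyl hydrazone. In this assay compound 2 returns only a limit, > 100000 nM, the point marked by the limit of > 100000 nM in this assay, at which 1 of the 2 values shown sits, so no number is known for it. Compound 3 `CC(C)(C)c1ccc(Cn2nc(-c3ccc(Cl)cc3)cc2C(=O)N/N=C/c2cccc(O)c2O)cc1` differs from compound 2 by 2,3-dihydroxyphenyl in place of 2,4-difluorophenyl on a carbon with a double bond to nitrogen. Going by the values given here, no measured pair covers this change directly. A step toward stronger inhibition, beyond the scatter, is expected because compound 1, bearing the same 2,3-dihydroxyphenyl group, gives 700 nM. The expected step is an at least 50-fold lower number from compound 2 to compound 3 (1.69 log units; beyond the scatter). Compound 3 is estimated at 2000 nM, with a range of 400 nM to 20000 nM.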

Compound 3, half-maximal inhibitory concentration: 400 nM
The estimate for compound 3 lay 5.0-fold (0.70 log units) above the measured number; low and high end bracket the measured number.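

On the carbon with a double bond to nitrogen, 2,3-dihydroxyphenyl in place of 2,4-difluorophenyl now stands as a direct pair in this assay, with an at least 250-fold lower number from compound 2 to compound 3 (2.39 log units; beyond the scatter) as the step. Its starting point is a limit and not a number: the limit of > 100000 nM in this assay, at which 1 of the 3 values shown sits. With the 2,3-dihydroxyphenyl hydrazone held fixed, 4-(tert-butyl)phenyl in place of 6-chloropyridin-3-yl on a saturated chain carbon bound to an aromatic nitrogen gives a 1.8-fold lower number from compound 1 to compound 3 (0.24 log units; within the scatter), so these two groups are not told apart at that place.

Whether both hydroxyl groups are needed stays open, since neither a single hydroxyl nor a 2,3-dimethoxyphenyl group on that carbon is among the compounds shown. Also open, as far as these compounds go, is how 2,4-difluorophenyl behaves when paired with 6-chloropyridin-3-yl rather than 4-(tert-butyl)phenyl.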